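This account rests on a few compounds, and the source may have more. Where it says the series, first, only, none or still open, it means among the compounds named here.

In a functional assay on MCF7 cells (Homo sapiens) for inhibition, read by MTT assay, with a stated time of 48 h, tested at 10 uM (on this read-out lower numbers stand for less inhibition of growth and higher numbers for more inhibition of growth at the one concentration tested), compound 2 (`CCOC(=O)N1CCN(Cc2c(O)c([C@H]3CCN(C)C[C@H]3O)c3oc(C)cc(=O)c3c2O)CC1`) gives 31% as the higher of two numbers, and compound 1 (`Cc1cc(=O)c2c(O)c(CN3CCCC3)c(O)c([C@H]3CCN(C)C[C@H]3O)c2o1`) gives 12% as the lower. Compound 3 (`Cc1cc(=O)c2c(O)c(CN(C(C)C)C(C)C)c(O)c([C@H]3CCN(C)C[C@H]3O)c2o1`) has diisopropylamino in place of 4-(ethoxycarbonyl)piperazin-1-yl on a saturated chain carbon bound to an aromatic carbon. Among the measured compounds shown here, only one measured step bears on this place, a number 19 percentage points higher from compound 1 to compound 2 (beyond the scatter), and with 4-(ethoxycarbonyl)piperazin-1-yl leaving again a modest fall in this assay is expected. The expected step is a number 13 percentage points lower from compound 2 to compound 3 (beyond the scatter) as estimated here. For compound 3 the estimate is 18% within an expected range of 5% to 34% for now.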

Compound 3, percent growth inhibition at one concentration: 33%
Beside the measured number, compound 3's estimate is 15 percentage points below it, and the stated range covers the measured number.
By their numbers in this assay, from the lowest: compound 1; then compounds 2 and 3 (each within the scatter of the next).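

In this assay, at the place on a saturated chain carbon bound to an aromatic carbon, diisopropylamino in place of 4-(ethoxycarbonyl)piperazin-1-yl gives a number 2 percentage points higher from compound 2 to compound 3 (within the scatter), so among these compounds the number of compound 2 does not depend on a ring or a double bond in this group. Diisopropylamino in place of pyrrolidin-1-yl gives a number 21 percentage points higher from compound 1 to compound 3 (beyond the scatter), leaving pyrrolidin-1-yl as the one group of the three set apart. No measurement shown here explains either step. On these data alone, whether dimethylamino, piperidin-1-yl or morpholin-4-yl would fall with compound 1 or with compound 3 remains open.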